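Cytotoxicity Limits Across Three Amides and a Fourth Analogue

The compounds below may be only part of what the source reports. "The series", "measured", "known", "first", "only" and "open" are said of these compounds alone.

Measured compounds:
- compound 1 `COc1cccc(-c2ccc(C(=O)N(Cc3cccc(OCCCCCC(=O)O)c3)C(C)C)cc2)c1`: > 20900 nM
- compound 2 `CC(C)N(Cc1cccc(OCCCCCC(=O)O)c1)C(=O)c1ccc(-c2ccc3[nH]ccc3c2)cc1`: > 26000 nM
- compound 3 `CCOC(=O)CCCCCOc1cccc(CN(C(=O)c2ccc(-c3cccc(OC)c3)cc2)C(C)C)c1`: > 21000 nM

All three were tested in an ADME assay on BJ cells (Homo sapiens) for cytotoxicity, read by CellTiter-Glo and resazurin assay, with a stated time of 72 h; on this read-out higher numbers stand for an effect only at larger amounts of compound and lower numbers for an effect already at smaller amounts. In this assay compound 1 gives > 20900 nM, which is a limit of the assay and not a number. Compound 2 gives > 26000 nM, again a limit. Compound 3 gives > 21000 nM, also a limit. Compound 4 `CCOC(=O)CCCCCOc1cccc(CN(C(=O)c2ccc(-c3ccc4[nH]ccc4c3)cc2)C(C)C)c1` has not yet been measured in this assay.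

Compound 2 differs from compound 1 by 1H-indol-5-yl in place of 3-methoxyphenyl on an aromatic carbon. The step that the two limits leave unreadable from compound 1 to compound 2 cannot be read, as both ends are limits: the limit of > 20900 nM in this assay, at which 1 of the 3 values shown sits, and (the limit of > 26000 nM in this assay, at which 1 of the 3 values shown sits). Compound 3 differs from compound 1 by ethyl in place of hydrogen on an oxygen next to a carbonyl group, and the step that the two limits leave unreadable from compound 1 to compound 3 is likewise unreadable from the limit of > 20900 nM in this assay, at which 1 of the 3 values shown sits, and (the limit of > 21000 nM in this assay, at which 1 of the 3 values shown sits).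

Compound 4 differs from compound 3 by 1H-indol-5-yl in place of 3-methoxyphenyl on an aromatic carbon, the same change, at the same place, that turns compound 1 into compound 2. Because the limit of > 21000 nM in this assay, at which 1 of the 3 values shown sits, and the limit of > 26000 nM in this assay, at which 1 of the 3 values shown sits, are both limits, nothing measured here points to a readable effect of this change. The step that the limit leaves unreadable from compound 3 to compound 4 is therefore expected to be small. For compound 4 the estimate is 40000 nM, with a range from 15000 nM to 100000 nM, and the assay is expected most likely to report only a limit again.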

Compound 4, half-maximal effective concentration: > 26000 nM
Compound 4: no number, only a limit; the forecaster's own chance of this, stated with the estimate: 85%; the middle value lies beyond the limit too.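

In this assay compound 4 gives > 26000 nM, which is a limit of the assay and not a number. Compound 2 and compound 3 also stand only at limits, so neither step leading to compound 4 can be read. The compounds shown leave open whether 1H-indol-5-yl in place of 3-methoxyphenyl, or ethyl in place of hydrogen, changes cytotoxicity at all, and at what concentration any of the four would show an effect.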